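A few compounds are considered here, and "the series" means these few. Any claim that something is new, unique, unknown or untested is made for them only; others in the source may bear on it.

Measured in a functional assay on MCF7 cells (Homo sapiens) for cytotoxicity, read by MTT assay, with a stated time of 96 h; a higher number here means a weaker inhibitor, a lower number a stronger inhibitor:
- Compound 1 `COc1cc(C(=O)c2cn(-c3ccccc3C)cc2-c2ccccc2)cc(OC)c1OC`: 2200 nM
- Compound 2 `COc1ccccc1-n1cc(C(=O)c2cc(OC)c(OC)c(OC)c2)c(-c2ccccc2)c1`: 150 nM
- Compound 3 `COc1cc(C(=O)c2cn(-c3cccc(Cl)c3)cc2-c2ccccc2)cc(OC)c1OC`: 150 nM

Compound 3 shares its number with compound 2, and both stand well under compound 1. The next compound, compound 4 `COc1cccc(-n2cc(C(=O)c3cc(OC)c(OC)c(OC)c3)c(-c3ccccc3)c2)c1`, is made from compound 3 by one change: methoxy in place of chloro on an aromatic carbon. In words, this is methoxy in place of chloro on an aromatic carbon, turning 3-chlorophenyl into 3-methoxyphenyl.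

Within the data shown here, no measured step makes this exact swap. The closest is 3-chlorophenyl in place of 2-methoxyphenyl on an aromatic nitrogen, which gave no change at the digits printed from compound 2 to compound 3 (within the scatter). Two other steps were large: methoxy in place of methyl gave a 15-fold lower number from compound 1 to compound 2 (1.17 log units; beyond the scatter), and 3-chlorophenyl in place of 2-methylphenyl gave a 15-fold lower number from compound 1 to compound 3 (1.17 log units; beyond the scatter). Both start from compound 1, so they bear less directly on a change made to compound 3.

In this assay, the expected result is no change at the digits printed from compound 3 to compound 4 (within the scatter), with no step beyond the scatter anticipated in either direction. For compound 4 the estimated value is 150 nM, with an expected range of 50 nM to 450 nM.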

Compound 4, half-maximal inhibitory concentration: 500 nM
Estimate against measurement, compound 4: 3.3-fold (0.52 log units) below, and the stated range ends below it.
By their numbers in this assay, from the lowest: compounds 2 and 3 (each within the scatter of the next); then compound 4; then compound 1.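

In this assay, the tie between compound 2 and compound 3 might suggest that these ring substituents are interchangeable, but two new steps show otherwise: exchanging chloro for methoxy at the same place gives a 3.3-fold higher number from compound 3 to compound 4 (0.52 log units; beyond the scatter), and moving the methoxy while keeping the group itself gives a 3.3-fold higher number from compound 2 to compound 4 (0.52 log units; beyond the scatter). The identity of the group and its place on the ring can therefore each shift the number, although 3-methoxyphenyl still does better than 2-methylphenyl, with a 4.4-fold lower number from compound 1 to compound 4 (0.64 log units; beyond the scatter). Nothing measured here explains why these changes have these effects.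

The compounds shown leave open how a hydroxy group, an amine or a longer ethoxy chain would fare in place of the methoxy. They also leave open whether chloro would keep its number elsewhere on this ring.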